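This account rests on a few compounds, and the source may have more. Where it says the series, first, only, none or still open, it means among the compounds named here.

Measured so far in an assay on HEK293 cells for displacement of a labelled ligand from prostaglandin D2 receptor 2 (Homo sapiens); on this read-out lower numbers stand for stronger inhibition and higher numbers for weaker inhibition:
compound 1, `O=C(O)Cn1c(SCCOc2ccc3ccccc3c2)nc2ccccc21`, 2500 nM
compound 2, `O=C(O)Cn1c(SCCc2ccccc2)nc2ccccc21`, 881 nM
compound 3, `O=C(O)Cn1c(SCCNc2ccccc2)nc2ccccc21`, 7690 nM

Of these three numbers compound 3 has the highest, meaning the weakest displacement: compound 1 sits lower and compound 2 lowest of all, and both gaps to compound 3 lie beyond the usual scatter. For the measured compounds named here, the only measured step that changes the same place is an 8.7-fold higher number from compound 2 to compound 3 (0.94 log units; beyond the scatter), where a plain aromatic ring gave way to a ring carrying a nitrogen.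

Compound 4, `CCOC(=O)CCSc1nc2ccccc2n1CC(=O)O`, is not yet measured. It differs from compound 3 by ethoxycarbonyl in place of anilino on a saturated chain carbon, two bonds along the chain from a sulfur. This swap removes the aromatic ring at that place entirely and leaves a short ester chain. Going by the values given here, no measured pair shows exactly this exchange; all three measured compounds keep an aromatic ring there, and the one change at that carbon was beyond the scatter. Relative to compound 3, with the ring gone, compound 4 is expected to move by a 1.6-fold higher number from compound 3 to compound 4 (0.19 log units; within the scatter). The estimate for compound 4 is therefore 12000 nM, with a range from 3000 nM to 45000 nM.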

Compound 4, half-maximal inhibitory concentration: 11400 nM
Beside the measured number, compound 4's estimate is 1.1-fold (0.02 log units) above it; low and high end bracket the measured number.
By their numbers in this assay, from the lowest: compound 2; then compound 1; then compounds 3 and 4 (each within the scatter of the next).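

In this assay, for the compounds shown here, all the earlier compounds kept an aromatic ring at this place, and ethoxycarbonyl now tests a group with no ring, with a 1.5-fold higher number from compound 3 to compound 4 (0.17 log units; within the scatter) as the result, so anilino and ethoxycarbonyl cannot be told apart here. Measured against phenyl, the same exchange gives a 13-fold higher number from compound 2 to compound 4 (1.11 log units; beyond the scatter) as a large step, which leaves phenyl clearly apart from both other groups on this saturated chain carbon, two bonds along the chain from a sulfur. Nothing at hand explains these differences.

Still open is whether any group without a ring can match phenyl here, as ethoxycarbonyl is the only such group shown. A plain butyl chain, an amide or a carboxylic acid on the same carbon would help to answer this.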